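The compounds below may be only part of what the source reports. "The series", "measured", "known", "first", "only" and "open" are said of these compounds alone.

Compound 1, `CCCCCCC#Cc1ccc(S(=O)(=O)Nc2cccc(-c3csc(NC(C)=O)n3)c2)cc1`, in a functional assay on A-375 cells (Homo sapiens) for antiproliferative activity, read by trypan blue exclusion, with a stated time of 48 h, tested at 5 uM (a lower number here means a stronger effect, a higher number a weaker effect of the compound at the concentration tested), gives 12.8%.
Compound 2, `CC(=O)Nc1nc(-c2cccc(NS(=O)(=O)c3ccc(C#C[Si](C)(C)C)cc3)c2)cs1`, in this assay gives 4.2%.
Compound 3, `C#Cc1ccc(S(=O)(=O)Nc2cccc(-c3csc(NC(C)=O)n3)c2)cc1`, in this assay gives 38.3%.

Compound 3 has the highest of the three numbers, which in this read-out means the weakest effect; the step of a number 25.5 percentage points higher from compound 1 to compound 3 (beyond the scatter) and the step of a number 34.1 percentage points higher from compound 2 to compound 3 (beyond the scatter) both lie beyond the scatter, while the step of a number 8.6 percentage points lower from compound 1 to compound 2 (within the scatter) does not. Compound 4, `CCCCCC/C=C\c1ccc(S(=O)(=O)Nc2cccc(-c3csc(NC(C)=O)n3)c2)cc1`, is the next compound. Compared with compound 3 it carries a group of 8 heavy atoms (8 carbon; no ring) in place of a group of 2 heavy atoms (2 carbon; no ring), on an aromatic carbon. The group that enters is a chain of eight carbon atoms with one double bond, whereas compound 1 carried a hexyl on a triple-bonded carbon and compound 2 a silicon-bearing group there. The two steps that bear on this change are a number 25.5 percentage points higher from compound 1 to compound 3 (beyond the scatter) and a number 34.1 percentage points higher from compound 2 to compound 3 (beyond the scatter): in each, taking a larger group off the triple bond raised the number, and compound 4 puts a larger group back. For the measured compounds named here, no measured pair shows a double bond in place of a triple bond, so the size of the step is uncertain. A step downward, back toward the number of compound 1, is therefore expected for compound 4, of about a number 23.3 percentage points lower from compound 3 to compound 4 (beyond the scatter). Compound 4 is estimated to give 15%, within a range from 4% to 35%.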

Compound 4, a percentage reported as activity, at one concentration (the size of the read-out at that concentration, not a potency): 2.3%
For compound 4 the middle estimate is 12.7 percentage points above the measured one, outside the stated range (below it).
By their numbers in this assay, from the lowest: compounds 4, 2 and 1 (each within the scatter of the next, the first and the last beyond it); then compound 3.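

Replacing the ethynyl with a chain of 8 carbons holding 1 double bond, on this aromatic carbon, gives a number 36 percentage points lower from compound 3 to compound 4 (beyond the scatter) in this assay and shows that a triple bond is not needed at this place for a low number. For the compounds shown here, compound 1 and compound 4 carry groups with the same count of 8 carbons, so the comparison of a number 10.5 percentage points lower from compound 1 to compound 4 (beyond the scatter) isolates a triple bond against a double bond and adds a step that no earlier pair could show, whereas the comparison of a number 1.9 percentage points lower from compound 2 to compound 4 (within the scatter) leaves the chain with the double bond and the silicon-bearing group unseparated in this read-out. Nothing among the available data explains why these groups differ in effect.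

As far as these compounds go, whether the double bond matters in itself remains open, since a saturated octyl chain would be needed to compare with compound 4 on the same aromatic carbon. From the compounds shown here alone, it is also open how a shorter chain with a double bond, or an eight-carbon chain ending in an amine or a carboxylic acid, would behave in this assay at this position.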